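A few compounds are considered here, and "the series" means these few. Any claim that something is new, unique, unknown or untested is made for them only; others in the source may bear on it.

Going by the values given here, in a functional assay on K562 cells (Homo sapiens) for cytotoxicity, read by MTT assay, with a stated time of 48 h (on this read-out lower numbers stand for stronger inhibition and higher numbers for weaker inhibition), compound 1 (`COc1ccc(-c2c(-c3cc(OC)c(OC)c(OC)c3)noc2NC(C)=O)cc1OC`) gives 3710 nM and compound 2 (`COc1cc(-c2noc(NC(C)=O)c2-c2ccc(Cl)cc2)cc(OC)c1OC`) gives 3620 nM, so compound 2 stands within the scatter of the only other measured compound. Compound 3 (`COc1cc(-c2noc(N(C(C)=O)C(C)=O)c2-c2ccc(Cl)cc2)cc(OC)c1OC`) differs from compound 2 by acetyl in place of hydrogen on an amide-type nitrogen. Among the compounds with values here, the one measured step, a 1.0-fold lower number from compound 1 to compound 2 (0.01 log units; within the scatter), lies within the scatter, but it concerns an aromatic carbon, and no measured step touches this nitrogen. Hence no step beyond the scatter is expected in this assay, on thin evidence. The estimated change is a 1.0-fold lower number from compound 2 to compound 3 (0.01 log units; within the scatter). Compound 3 is estimated at 3500 nM, with an expected range of 1000 nM to 12000 nM.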

Compound 3, half-maximal inhibitory concentration: 3960 nM
Estimate against measurement, compound 3: 1.1-fold (0.05 log units) below, and the stated range covers the measured number.
By their numbers in this assay, from the lowest: compounds 2, 1 and 3 (each within the scatter of the next).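

In this assay, going by these compounds alone, acetyl in place of hydrogen on the amide-type nitrogen, turning acetamido into diacetylamino, gives a 1.1-fold higher number from compound 2 to compound 3 (0.04 log units; within the scatter) and is the first measured step at this nitrogen. With the 4-chlorophenyl group in place, the amide hydrogen can therefore be replaced by a second acetyl without a step beyond the scatter. No evidence on any other property bears on this result. On these data alone, it remains open whether a free amine or a longer chain such as butanoyl on this nitrogen would behave alike. As far as these compounds go, it also remains open whether the second acetyl would give a similar result with the 3,4-dimethoxyphenyl group of compound 1.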